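From tert-butyl to methyl on the shared core

A few compounds are considered here, and "the series" means these few. Any claim that something is new, unique, unknown or untested is made for them only; others in the source may bear on it.

Going by the values given here, in an ADME assay on CHO cells (Cricetulus griseus) for inhibition, read by MTT assay (on this read-out higher numbers stand for weaker inhibition and lower numbers for stronger inhibition), compound 2 `CC(C)(C)NCc1cc(C(C)(C)C)cc(Nc2nc3ccccc3[nH]2)c1O` gives 30500 nM, the only actual number so far. Compound 1 `CC(C)(C)NCc1cc(Cl)cc(Nc2nc3ccccc3[nH]2)c1O` reads > 50000 nM, which is a limit of the assay. Compound 3 `Cc1cc(CNC(C)(C)C)c(O)c(Nc2nc3ccccc3[nH]2)c1` carries methyl in place of tert-butyl on an aromatic carbon, para to a hydroxy group (methyl in place of tert-butyl on an aromatic carbon). Among the compounds with values here, the one measured step at this carbon, an at least 1.6-fold lower number from compound 1 to compound 2 (0.21 log units; that floor lies within the scatter), exchanged chloro for tert-butyl, so no change beyond the scatter is expected here. The expected step is a 1.4-fold higher number from compound 2 to compound 3 (0.14 log units; within the scatter). For compound 3, the estimated value is 42000 nM, with an expected range from 22000 nM to 80000 nM.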

Compound 3, half-maximal inhibitory concentration: 33300 nM
Compound 3: middle estimate off by 1.3-fold (0.10 log units), on the high side; low and high end bracket the measured number.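

In this assay, going by these compounds alone, methyl in place of tert-butyl on this aromatic carbon gives a 1.1-fold higher number from compound 2 to compound 3 (0.04 log units; within the scatter), the first comparison here between two actual numbers, and it shows that these two groups cannot be told apart at this position. Methyl in place of chloro gives an at least 1.5-fold lower number from compound 1 to compound 3 (0.17 log units; that floor lies within the scatter), a floor that shows no change beyond the scatter. The value for compound 1 remains a limit, so the true size of this step cannot be read: the limit of > 50000 nM in this assay, at which 1 of the 3 values shown sits.

As far as these compounds go, whether an amine, a carboxylic acid or a methoxy group on this carbon would read differently stays open.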